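Carboxymethyl to 1-carboxyethyl on compound 3

The compounds below may be only part of what the source reports. "The series", "measured", "known", "first", "only" and "open" are said of these compounds alone.

Measured so far in an ADME assay on the whole organism (Mus musculus, strain CD1) for metabolic stability, read by LC-MS, with a stated time of 24 h, at a dose of 1 mg/kg by the intravenous route (on this read-out lower numbers stand for a shorter-lived compound and higher numbers for a longer-lived compound), for the series:
- compound 1 `O=C(O)Cn1nc(Cc2nc3cc(Cl)c(OCC(F)F)cc3[nH]2)c2ccccc2c1=O` gives 0.3 h
- compound 2 `O=C(O)Cn1nc(Cc2cn3cc(OCC4CC4)c(Cl)cc3n2)c2ccccc2c1=O` gives 0.7 h
- compound 3 `O=C(O)Cn1nc(Cn2cc3cc(OCC4CC4)c(Cl)cc3n2)c2ccccc2c1=O` gives 1.4 h

Compound 3 with 1.4 h stands beyond the scatter above compound 1, and compound 2 lies within the scatter of compound 3. These three compounds differ from each other in more than one place, so the values offer no direct measure of any single change.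

Compound 4 `C[C@H](C(=O)O)n1nc(Cn2cc3cc(OCC4CC4)c(Cl)cc3n2)c2ccccc2c1=O` is the next structure to be read. It differs from compound 3 by methyl in place of hydrogen on a saturated chain carbon bound to an aromatic nitrogen and a carbonyl carbon in one place only: methyl in place of hydrogen on a saturated chain carbon bound to an aromatic nitrogen and a carbonyl carbon. The same difference reads carboxymethyl to 1-carboxyethyl.

For the measured compounds named here, no measured pair shows what this change does to the half-life, so the expectation starts from compound 3 with 1.4 h as its anchor. The expected outcome is no change beyond the scatter, with only a slight lean towards a longer-lived compound. The estimated 1.3-fold higher number from compound 3 to compound 4 (0.11 log units; within the scatter) is small on that view. In this assay the estimate for compound 4 is 1.8 h with an expected range from 0.8 h to 4 h for a repeat measurement.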

Compound 4, half-life: 2.4 h
The estimate for compound 4 lay 1.3-fold (0.12 log units) below the measured number; the range from low to high includes it.
By their numbers in this assay, from the lowest: compound 1; then compounds 2, 3 and 4 (each within the scatter of the next, the first and the last beyond it).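

For the compounds shown here, this is the first comparison that isolates a single change. In this assay, methyl in place of hydrogen on a saturated chain carbon bound to an aromatic nitrogen and a carbonyl carbon gives a 1.7-fold higher number from compound 3 to compound 4 (0.23 log units; within the scatter). This position therefore accepts carboxymethyl to 1-carboxyethyl, with the carboxylic acid kept, without a step beyond the scatter on this core, although this single pair cannot separate a small real gain from repeat variation, and no measurement is available to explain the step.

Open questions remain at the same saturated chain carbon: whether the opposite configuration, a second methyl or an ethyl group would give a step of a different size in this assay. Going by these compounds, it is also open whether the same methyl would behave similarly on the cores of compound 1 and compound 2, and whether replacing the carboxylic acid with a tetrazole or a primary amide would leave the half-life within the scatter of compound 4.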